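A few compounds are considered here, and "the series" means these few. Any claim that something is new, unique, unknown or untested is made for them only; others in the source may bear on it.

Compound 2 `CS(=O)(=O)Nc1cccc(C(=O)N2CCCC(C(=O)Nc3ccc(Cl)cc3)C2)c1` gives 3% in an ADME assay on PC-3 cells (Homo sapiens) for cytotoxicity, read by WST assay, tested at 100 uM; on this read-out higher numbers stand for more inhibition at the one concentration tested (going by the name of the read-out) and lower numbers for less inhibition. Among the compounds with values here, of the two numbers measured so far, compound 2 and compound 1 `O=C(Nc1ccc(Cl)cc1)C1CCCN(C(=O)c2cccc(-c3cccs3)c2)C1` stand within the scatter of each other, compound 1 giving 4% in this assay. Within the data shown here, the only measured step, a number 1 percentage points lower from compound 1 to compound 2 (within the scatter), left the read-out essentially where it was. Compound 3 `COCc1cccc(C(=O)N2CCCC(C(=O)Nc3ccc(Cl)cc3)C2)c1` differs from compound 2 by methoxymethyl in place of methanesulfonamido on an aromatic carbon. Among the measured compounds shown here, no measured step involves methoxymethyl; the one step available also changed a group on an aromatic carbon of the shared core and stayed within the scatter, and both measured values sit at the weak end of the read-out. Compound 3 is therefore expected to show a number 1 percentage points higher from compound 2 to compound 3 (within the scatter), that is, nothing beyond the scatter. The estimate for compound 3 is 4%, with a range from 0% to 12%.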

Compound 3, a percentage reported as inhibition, at one concentration (the size of the read-out at that concentration, not a potency): 0%
Estimate against measurement, compound 3: 4 percentage points above, within the range that was stated.
By their numbers in this assay, from the lowest: compounds 3, 2 and 1 (each within the scatter of the next).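

In this assay, the place on the aromatic carbon, meta to a large group, now holds a third group, and methoxymethyl in place of methanesulfonamido gives a number 3 percentage points lower from compound 2 to compound 3 (within the scatter), while methoxymethyl in place of thiophen-2-yl gives a number 4 percentage points lower from compound 1 to compound 3 (within the scatter). The series therefore now includes a group with 0 hydrogen-bond donors alongside methanesulfonamido with 1 hydrogen-bond donor and a thiophen-2-yl group with a ring, yet all three compounds stand within the scatter of each other. Nothing available accounts for this reading. The compounds shown leave open whether an amine, a carboxylic acid or a longer chain at this place would move the read-out beyond the scatter. They also leave open whether a change elsewhere on the shared core would do so.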